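The compounds below may be only part of what the source reports. "The series", "measured", "known", "first", "only" and "open" are said of these compounds alone.

Measured so far in a functional assay, with a stated time of 10 min; on this read-out higher numbers stand for weaker inhibition and lower numbers for stronger inhibition
- Compound 1 `O=c1cc(/C=C/c2ccccc2)[nH]cc1O` gives 4030 nM
- Compound 2 `O=c1cc(/C=C/c2ccc(Cl)cc2)[nH]cc1O` gives 11500 nM
- Compound 3 `Cn1cc(O)c(=O)cc1/C=C/c1ccc(Cl)cc1` gives 5720 nM

Compound 3 at 5720 nM lies within the usual scatter of both compound 1 and compound 2. Compound 4 `Cn1cc(O)c(=O)cc1/C=C/c1ccc(O)cc1` differs from it hydroxy in place of chloro on an aromatic carbon with hydroxy in place of chloro on an aromatic carbon. The nearest evidence is a 2.9-fold higher number from compound 1 to compound 2 (0.46 log units; beyond the scatter) on putting chloro in place of hydrogen on an aromatic carbon. The step of a 2.0-fold lower number from compound 2 to compound 3 (0.30 log units; within the scatter) with methyl in place of hydrogen on an aromatic nitrogen concerns a different place and says little here. Among the compounds with values here, no measured compound carries hydroxy at this spot, so only a modest step is expected. The expected change is a 2.3-fold lower number from compound 3 to compound 4 (0.36 log units; beyond the scatter) in this assay and remains uncertain. For compound 4 the estimated value is 2500 nM (range 700 nM to 8000 nM).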

Compound 4, half-maximal inhibitory concentration: 1370 nM
Beside the measured number, compound 4's estimate is 1.8-fold (0.26 log units) above it; the measured number falls inside the stated range.
By their numbers in this assay, from the lowest: compound 4; then compounds 1, 3 and 2 (each within the scatter of the next, the first and the last beyond it).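

In this assay, hydroxy in place of chloro on the aromatic carbon gives a 4.2-fold lower number from compound 3 to compound 4 (0.62 log units; beyond the scatter). The earlier change at this spot, a 2.9-fold higher number from compound 1 to compound 2 (0.46 log units; beyond the scatter), went towards weaker inhibition, whereas this one shows that a swap here can also move the number towards stronger inhibition. Nothing available explains why this swap has this result. The compounds shown leave open whether an amine or a methoxy group at this spot would give a similar number, and whether hydroxy would act the same way on the core of compound 1.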